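The compounds below may be only part of what the source reports. "The series", "measured", "known", "first", "only" and "open" are said of these compounds alone.

Compound 1 `CN1[C@@H]2c3[nH]c4ccccc4c3C[C@H]1[C@H](C#N)N1[C@@H](CNC(=O)c3cccc(C(F)(F)F)c3)c3[nH]c4ccccc4c3C[C@@H]21` and compound 2 `COc1ccc(C(=O)NC[C@H]2c3[nH]c4ccccc4c3C[C@H]3[C@H]4c5[nH]c6ccccc6c5C[C@@H]([C@H](C#N)N23)N4C)cc1` share one core and differ only in the aromatic group attached to the amide carbonyl. In a functional assay on HepG2 cells (Homo sapiens) for cytotoxicity, read by MTT assay, with a stated time of 72 h (a higher number here means a weaker inhibitor, a lower number a stronger inhibitor), compound 1 gives 340 nM, and compound 2 gives 310 nM. Among the compounds with values here, the step of a 1.1-fold lower number from compound 1 to compound 2 (0.04 log units; within the scatter) shows that the two numbers sit within the scatter of one another, so no order can be read between them; compound 2 merely carries the smaller of the two numbers so far recorded, and that gap is within the scatter. Compound 3 `CN1[C@@H]2c3[nH]c4ccccc4c3C[C@H]1[C@H](C#N)N1[C@@H](CNC(=O)c3cccc4c3CCCC4)c3[nH]c4ccccc4c3C[C@@H]21` is the next member of the series, and its change from compound 2 is 1,2,3,4-tetrahydronaphthalen-5-yl in place of 4-methoxyphenyl on a carbonyl carbon. Within the data shown here, the only measured step that bears on this change is a 1.1-fold lower number from compound 1 to compound 2 (0.04 log units; within the scatter), which also exchanged one aromatic group on the same carbonyl carbon and moved the number by an amount within the scatter. Among the measured compounds shown here, with only that step to go on, compound 3 is expected to shift by a 1.1-fold higher number from compound 2 to compound 3 (0.05 log units; within the scatter), that is, by nothing beyond the scatter. Compound 3 is therefore estimated at 350 nM, in a range from 150 nM to 800 nM.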

Compound 3, half-maximal inhibitory concentration: 540 nM
Compound 3: the middle estimate sits 1.5-fold (0.19 log units) below what was measured; the range from low to high includes it.
By their numbers in this assay, from the lowest: compounds 2, 1 and 3 (each within the scatter of the next).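

Compound 3 brings to the carbonyl carbon a group that differs from the two before it in kind: 1,2,3,4-tetrahydronaphthalen-5-yl carries a six-membered non-aromatic ring of carbon only on top of its aromatic ring, and it has no hydrogen-bond acceptor, where the 4-methoxyphenyl has one. In this assay this change reads as a 1.7-fold higher number from compound 2 to compound 3 (0.24 log units; within the scatter) and the exchange for the 3-(trifluoromethyl)phenyl group reads as a 1.6-fold higher number from compound 1 to compound 3 (0.20 log units; within the scatter), so across the three compounds shown, the added ring and the loss of the oxygen leave no difference at this position that can be told from the scatter. Nothing measured here offers an account of these numbers.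

All three groups on this carbonyl carbon hold a six-membered aromatic ring of carbon only, so the position has been seen with only a narrow range of groups. Going by these compounds, it remains open whether a group of another kind, such as an amine, a carboxylic acid or a longer alkyl chain, would move the number beyond the scatter in this assay.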